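A few compounds are considered here, and "the series" means these few. Any claim that something is new, unique, unknown or untested is made for them only; others in the source may bear on it.

Going by the values given here, in a physicochemical assay for lipophilicity (a higher number here means a more lipophilic compound, a lower number a more polar compound), compound 1 (`CCn1nc(Cn2nnnc2-c2ccccn2)cc1C`) gives 1.34, the lower of the two numbers so far, while compound 2 (`CCn1nc(Cn2nnnc2Cc2ccccc2)cc1C`) gives 2.1. Compound 3 (`Cc1cc(Cn2nnnc2-c2ccccn2)n[nH]1`) has not yet been measured. It carries hydrogen in place of ethyl on an aromatic nitrogen. Among the compounds with values here, the only measured step, a number 0.76 log units higher from compound 1 to compound 2 (beyond the scatter), changes a different group, so it serves only as a loose guide to size. A step of similar size, downward in this assay, is therefore expected, and the estimated change is a number 0.84 log units lower from compound 1 to compound 3 (beyond the scatter). For compound 3 the expected value is 0.5, with an estimated range of 0.1 to 0.9.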

Compound 3, partition coefficient: 0.86
Compound 3: the middle estimate sits 0.36 log units below what was measured; the range from low to high includes it.
By their numbers in this assay, from the lowest: compound 3; then compound 1; then compound 2.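

In this assay the ethyl on the aromatic nitrogen proves to be a place where the number moves: hydrogen in its place gives a drop (a number 0.48 log units lower from compound 1 to compound 3 (beyond the scatter)). Going by these compounds alone, until now only the group on the aromatic carbon had been varied, so this is the only reading for the other end of the core. Nothing measured here explains the shift. The compounds shown leave open how a longer chain such as propyl, or a chain ending in an amine, would read at this nitrogen. They also leave open whether hydrogen in place of ethyl gives a similar step with benzyl in place of pyridin-2-yl.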